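A few compounds are considered here, and "the series" means these few. Any claim that something is new, unique, unknown or untested is made for them only; others in the source may bear on it.

Measured so far in a functional assay on L1210 cells (Mus musculus) for inhibition; a lower number here means a stronger inhibitor, a higher number a weaker inhibitor:
- compound 1 `C=C1[C@H](n2ccc(=O)[nH]c2=O)O[C@H](CO)[C@H]1O`: > 500000 nM, a limit
- compound 2 `C=C1[C@@H](O)[C@H](n2cnc3c(Cl)nc(N)nc32)O[C@@H]1CO`: 441000 nM
- compound 3 `C=C1[C@@H](O)[C@H](n2cnc3c(O)nc(N)nc32)O[C@@H]1CO`: > 200000 nM, a limit

In this assay compound 3 stands at > 200000 nM, which is a limit and not a number. Compound 4 `C=C1[C@@H](O)[C@H](n2cnc3c(OC)nc(N)nc32)O[C@@H]1CO` differs from it by methyl in place of hydrogen on an oxygen on an aromatic ring, or hydroxy to methoxy. Within the data shown here, the one measured step that bears on this is a step that the limit leaves unreadable from compound 2 to compound 3, also a change on an aromatic ring of the shared core, and it offers no size to carry over. Among these compounds only compound 2 has a number, 441000 nM. Nothing measured points to a large gain, so no step beyond the scatter is expected, and no direction can be read. The expected step is a step that the limit leaves unreadable from compound 3 to compound 4. Compound 4 is estimated at 300000 nM, with an expected range of 100000 nM to 600000 nM.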

Compound 4, half-maximal inhibitory concentration: 446000 nM
The estimate for compound 4 lay 1.5-fold (0.17 log units) below the measured number; low and high end bracket the measured number.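

In this assay, methoxy gives this aromatic carbon on the shared core a second number, and the change from chloro to methoxy leaves the read-out within the scatter (a 1.0-fold higher number from compound 2 to compound 4 (0.00 log units; within the scatter)). Compound 3 carries only a limit (> 200000 nM). The steps to and from compound 3 therefore cannot be read, so methylation of the hydroxy group has no measurable size here: the limit of > 200000 nM in this assay, at which 1 of the 4 values shown sits.

Whether hydroxy differs at all from chloro or methoxy remains open, since the compounds shown give no number for hydroxy. On these data alone, it is also open whether an amine, a thiol or a longer chain such as ethoxy on this aromatic carbon would move the number in this assay beyond the scatter.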